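This account rests on a few compounds, and the source may have more. Where it says the series, first, only, none or still open, it means among the compounds named here.

Among the measured compounds shown here, the series shares one core carrying an aryl amine, and the three measured members differ only in the aryl group on that nitrogen. Compound 1 `COc1ccccc1Nc1nc(-c2cccc(F)c2)nc2ccc(F)cc12` carries a 2-methoxyphenyl there. In a functional assay on MDA-MB-231 cells (Homo sapiens) for cytotoxicity, read by MTT assay, with a stated time of 48 h (a higher number here means a weaker inhibitor, a lower number a stronger inhibitor), compound 1 gives > 50000 nM, which is a limit of the assay and not a number. Compound 2 `Fc1ccc(Nc2nc(-c3cccc(F)c3)nc3ccc(F)cc23)cc1` carries a 4-fluorophenyl. In this assay compound 2 gives > 50000 nM, again a limit. Compound 3 `Fc1cccc(-c2nc(Nc3cccc(Cl)c3)c3cc(F)ccc3n2)c1` carries a 3-chlorophenyl. In this assay compound 3 gives > 50000 nM, also a limit. So compound 3 stands where every measured member stands: the limit of > 50000 nM in this assay, at which 3 of the 3 values shown sit. The steps a step that the two limits leave unreadable from compound 1 to compound 2, a step that the two limits leave unreadable from compound 1 to compound 3 and a step that the two limits leave unreadable from compound 2 to compound 3 are consequently unreadable in size; all the measurements show is that none of these three aryl groups brings the value into the readable range. Compound 4 `Fc1cccc(-c2nc(Nc3ccccc3Br)c3cc(F)ccc3n2)c1` is the next member: 2-bromophenyl in place of 3-chlorophenyl on a nitrogen on an aromatic ring. For the measured compounds named here, no measured step reads a size for a change of this kind, so the expectation rests on the three limits alone, and compound 4 is expected to sit at the limit as well. The step of a number no higher from compound 3 to compound 4 (the limit leaves the size open) is expected to be about flat, and the estimate for compound 4 is 50000 nM with a range of 20000 nM to 200000 nM.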

Compound 4, half-maximal inhibitory concentration: > 50000 nM
Compound 4: no number, only a limit; the forecaster's own chance of this, stated with the estimate: 85%; the middle value lies on the limit itself.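

The steps joining compound 4 to compound 1, compound 2 and compound 3 cannot be read in size, since all four sit at a limit and not a number: the limit of > 50000 nM in this assay, at which 4 of the 4 values shown sit. The compounds shown leave open whether any aryl group on that nitrogen brings the value into the readable range.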